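This account rests on a few compounds, and the source may have more. Where it says the series, first, only, none or still open, it means among the compounds named here.

Of the compounds shown here, three with a shared core have been measured in a functional assay on WM 266-4 cells (Homo sapiens) for inhibition, read by MTT assay, with a stated time of 24 h; on this read-out lower numbers stand for stronger inhibition of growth and higher numbers for weaker inhibition of growth. Compound 1 `COc1ccc(C2=NN(C(=O)c3ccc4c(c3)OCCO4)C(c3ccc(F)cc3)C2)cc1` gives 3780 nM. Compound 2 `COc1ccc(C2=NN(C(=O)C3COc4ccccc4O3)C(c3cccc(F)c3)C2)cc1` gives 6720 nM, the highest of the three numbers, though its gap to compound 1 lies within the scatter of the measurement. For the measured compounds named here, compound 3 `O=C(C1COc2ccccc2O1)N1N=C(c2ccccc2)CC1c1cccc(F)c1` gives 1450 nM, and the step of a 4.6-fold lower number from compound 2 to compound 3 (0.67 log units; beyond the scatter) is the only change beyond the scatter seen so far. Compound 4 `COc1ccc(C2=NN(C(=O)C3COc4ccccc4O3)C(c3ccccc3)C2)cc1` is not yet measured. It differs from compound 2 by hydrogen in place of fluoro on an aromatic carbon; read one bond further out, the same difference is 3-fluorophenyl to phenyl. Going by the values given here, none of the measured steps removes a fluoro: the one step recorded, from compound 2 to compound 3, takes away a methoxy on the other ring, so it says nothing direct about this change. Compound 1 and compound 2 differ in where the fluoro sits and in the ring joined to the carbonyl, so their two values show only that both fall in the same range. With nothing measured pointing either way, the step of a 1.1-fold lower number from compound 2 to compound 4 (0.05 log units; within the scatter) is expected to stay within the scatter. Compound 4 is estimated at 6000 nM, with a range from 2500 nM to 15000 nM.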

Compound 4, concentration for 50% growth inhibition: 6310 nM
The estimate for compound 4 lay 1.1-fold (0.02 log units) below the measured number, within the range that was stated.
By their numbers in this assay, from the lowest: compound 3; then compounds 1, 4 and 2 (each within the scatter of the next).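

In this assay there is a 1.1-fold lower number from compound 2 to compound 4 (0.03 log units; within the scatter), so compound 2 and compound 4 cannot be told apart, and fluoro and hydrogen read alike at this place on the aromatic ring, meta to a large group. For the compounds shown here, this is the first direct reading of that change, as the only earlier step, a 4.6-fold lower number from compound 2 to compound 3 (0.67 log units; beyond the scatter), concerned the methoxy on the other ring and left the fluoro in place. No other measurement is at hand to explain the result.

On these data alone, whether a different group at this place, such as an amine, a carboxylic acid or a longer chain, would give a number beyond the scatter remains open. As far as these compounds go, it is also open whether fluoro and hydrogen would read alike on compound 3, which carries no methoxy.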